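The source may hold more compounds than are shown below. What is called first, only, known or untested is meant among the compounds shown, and "the series" means these compounds.

Compound 1 `C/C(=N\NC(=O)c1cccc(S(=O)(=O)N2CCOCC2)c1)c1cccc(O)c1` gives in a functional assay on PC-3 cells (Homo sapiens) for antiproliferative activity, read by MTT assay, with a stated time of 72 h (a higher number here means a weaker inhibitor, a lower number a stronger inhibitor), the value > 100000 nM, which is a limit of the assay.
Compound 2 `C/C(=N\NC(=O)c1cccc(S(=O)(=O)N2CCOCC2)c1)c1cccc(N)c1O` gives 2330 nM in this assay.
Compound 3 `O=C(N/N=C/c1ccco1)c1cccc(S(=O)(=O)N2CCOCC2)c1` gives > 100000 nM in this assay, again a limit.

Compound 3 thus sits at the limit of > 100000 nM in this assay, at which 2 of the 3 values shown sit, with no number of its own. Compound 4 `O=C(N/N=C/c1cc(Cl)ccc1O)c1cccc(S(=O)(=O)N2CCOCC2)c1` differs from it by 5-chloro-2-hydroxyphenyl in place of furan-2-yl on a carbon with a double bond to nitrogen. Among the compounds with values here, the only measured step, an at least 42-fold lower number from compound 1 to compound 2 (1.63 log units; beyond the scatter), concerns a different aryl group and only partly bears on this change; it shows that a hydroxyphenyl bearing a second substituent can move a compound away from the limit. An estimate for compound 4 is therefore uncertain, and an improvement of an at least 3.3-fold lower number from compound 3 to compound 4 (0.52 log units; beyond the scatter) is expected at most. Compound 4 is estimated at 30000 nM, between 3000 nM and 100000 nM.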

Compound 4, half-maximal inhibitory concentration: 10500 nM
Compound 4: middle estimate off by 2.9-fold (0.46 log units), on the high side; the range from low to high includes it.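

In this assay, 5-chloro-2-hydroxyphenyl in place of furan-2-yl on a carbon with a double bond to nitrogen gives an at least 9.5-fold lower number from compound 3 to compound 4 (0.97 log units; beyond the scatter). The earlier step showed a departure from the limit only between two hydroxyphenyl groups, whereas this one shows it for an exchange of the ring itself. Compound 3 stands at a limit, so this step has a lower bound only: the limit of > 100000 nM in this assay, at which 2 of the 4 values shown sit.

The compounds shown do not separate the chlorine from the hydroxyl, which enter together with the six-membered ring. Open too, from the compounds shown here alone, is whether an amine or a methoxy group in place of the chlorine would lower the number further.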